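The source may report more compounds than this note shows. Statements on the series, on what has been measured and on what is new or still open speak of the compounds shown alone.

Measured so far:
compound 1 `CCOc1ccccc1-n1nncc1CN1C(=O)C2(C(C#N)=C(N)Oc3c(N)cc4nc5ccccc5nc4c32)c2ccccc21` — in a functional assay on HepG2 cells (Homo sapiens) for antiproliferative activity, read by MTT assay, with a stated time of 48 h (on this read-out higher numbers stand for weaker inhibition and lower numbers for stronger inhibition), compound 1 gives 30500 nM
compound 2 `N#CC1=C(N)Oc2c(N)cc3nc4ccccc4nc3c2C12C(=O)N(Cc1cnnn1-c1ccc(Cl)cc1[N+](=O)[O-])c1ccccc12` — for compound 2 this assay reports only a limit, > 50000 nM

Compound 2 stands at that limit (the limit of > 50000 nM in this assay, at which 1 of the 2 values shown sits), so its number is not known. Within the data shown here, the one measured step, an at least 1.6-fold higher number from compound 1 to compound 2 (0.21 log units; that floor lies within the scatter), is the only one that bears here, and its floor lies within the scatter. Compound 3 `COc1cc(-n2nncc2CN2C(=O)C3(C(C#N)=C(N)Oc4c(N)cc5nc6ccccc6nc5c43)c3ccccc32)c(OC)cc1Cl` differs from compound 2 by 4-chloro-2,5-dimethoxyphenyl in place of 4-chloro-2-nitrophenyl on an aromatic nitrogen. Both changes so far swap the group on the aromatic nitrogen, and the data give no direction for this one beyond the scatter. Compound 3 is estimated at 45000 nM (range 15000 nM to 120000 nM), an expected step of an at least 1.1-fold lower number from compound 2 to compound 3 (0.04 log units; that floor lies within the scatter).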

Compound 3, half-maximal inhibitory concentration: > 50000 nM
Compound 3 gave a limit, no number; the forecaster's own chance of this, stated with the estimate: 45%; at least 1.1-fold (0.04 log units) between middle value and limit.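

In this assay compound 3 returns only a limit, not a number, and the steps that its limit and that of compound 2 leave between them cannot be read. The change from 2-ethoxyphenyl to 4-chloro-2,5-dimethoxyphenyl on the aromatic nitrogen gives an at least 1.6-fold higher number from compound 1 to compound 3 (0.21 log units; that floor lies within the scatter) and so shows no firm separation from compound 1. A second chlorinated aryl group now sits at the same limit: the limit of > 50000 nM in this assay, at which 2 of the 3 values shown sit.

Going by these compounds, how far compound 2 and compound 3 lie past that limit remains open. Also open, on these data alone, is whether an amine or a carboxylic acid on this phenyl ring, or a longer alkoxy chain in place of the ethoxy group, would give a readable number.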